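This account rests on a few compounds, and the source may have more. Where it says the series, first, only, none or still open, it means among the compounds named here.

Compound 1 `COc1ccc(Oc2ccccc2-c2ccsc2S(=O)(=O)N2CCN(C(=O)Nc3ccc([N+](=O)[O-])cc3)CC2)cc1OC`; compound 2 `O=C(NCCNS(=O)(=O)c1ccc(-c2ccccc2Oc2ccc(O)c(O)c2)s1)Nc1cc(Cl)cc(Cl)c1`; compound 3 `O=S(=O)(NCCNC(=S)Nc1ccc(Cl)cc1)c1ccc(-c2ccccc2OCc2ccccc2)s1`.

In a functional assay on HeLa cells (Homo sapiens) for inhibition, read by CCK-8 assay, with a stated time of 48 h (a lower number here means a stronger inhibitor, a higher number a weaker inhibitor), compound 1 gives only a limit, > 50000 nM. Compound 2 likewise gives only a limit in this assay, > 20000 nM. Compound 3 gives 7000 nM in this assay. Within the data shown here, compound 2 thus stands at a limit (the limit of > 20000 nM in this assay, at which 1 of the 3 values shown sits), one further value is also a limit (the limit of > 50000 nM in this assay, at which 1 of the 3 values shown sits), and the single measured number belongs to compound 3.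

Compound 4 `O=C(NCCNS(=O)(=O)c1ccc(-c2ccccc2Oc2ccc([N+](=O)[O-])c([N+](=O)[O-])c2)s1)Nc1cc(Cl)cc(Cl)c1` differs from compound 2 in one place: 3,4-dinitrophenyl in place of 3,4-dihydroxyphenyl on an oxygen on an aromatic ring. Among the measured compounds shown here, no step between two measured compounds follows this kind of change, so its size is uncertain. Compound 2 sits at a limit. The step of a number no higher from compound 2 to compound 4 (the limit leaves the size open) is expected to stay within the scatter, in no clear direction. Compound 4 is therefore estimated at 20000 nM, ranging from 4000 nM to 80000 nM, and a limit rather than a number is likely.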

Compound 4, half-maximal inhibitory concentration: > 20000 nM
Compound 4: a limit, no number; the forecaster's own chance of this, stated with the estimate: 55%; the middle value sits exactly at the limit.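

Among these compounds, compound 2 and compound 4 each give only a limit in this assay, so no step between them can be read. The compounds shown leave open whether 3,4-dinitrophenyl in place of 3,4-dihydroxyphenyl changes inhibition at all.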